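Pyrazole carboxylic acid series: aryl change at the pyrazole carbon

The compounds below may be only part of what the source reports. "The series", "measured", "known", "first", "only" and "open" are said of these compounds alone.

Of the compounds shown here, two carry numbers so far. Compound 1 `COc1ccc(-c2c(C)nn(-c3nc(-c4ccc(Cl)c(Cl)c4)c(SC(C)C)s3)c2C(=O)O)cc1` gives 2100 nM in a functional assay on BJAB cells (Homo sapiens) for antiproliferative activity, with a stated time of 4 days; on this read-out lower numbers stand for an effect already at smaller amounts and higher numbers for an effect only at larger amounts of compound. For the measured compounds named here, compound 2 `Cc1cc(-c2c(C)nn(-c3nc(-c4ccc(Cl)c(Cl)c4)c(SC(C)C)s3)c2C(=O)O)cc(C)n1` gives 580 nM in this assay and stands lowest of the two, the only neighbour being compound 1. Going by the values given here, the one measured step, a 3.6-fold lower number from compound 1 to compound 2 (0.56 log units; beyond the scatter), is the sole guide to what the aryl group at this position does.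

Compound 3 `COc1ccc(C)cc1-c1c(C)nn(-c2nc(-c3ccc(Cl)c(Cl)c3)c(SC(C)C)s2)c1C(=O)O` is the next candidate. The change from compound 2 is 2-methoxy-5-methylphenyl in place of 2,6-dimethylpyridin-4-yl on an aromatic carbon. This is a return from the pyridine ring of compound 2 toward a carbon-only ring resembling that of compound 1, though with a different pattern of methoxy and methyl groups. The step from compound 1 to compound 2 bears on it in reverse, so a higher number in this assay is expected for compound 3, roughly undoing that step, with a 2.6-fold higher number from compound 2 to compound 3 (0.41 log units; beyond the scatter) as the expected size. Among the compounds with values here, compound 3 is therefore estimated at 1500 nM, in a range from 500 nM to 4500 nM, the spread reflecting that only one prior step informs it.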

Compound 3, half-maximal effective concentration: 9500 nM
Compound 3: middle estimate off by 6.3-fold (0.80 log units), on the low side, and the stated range ends below it.
By their numbers in this assay, from the lowest: compound 2; then compound 1; then compound 3.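

In this assay, a carbon-only ring at this position does not by itself return the number to that of compound 1: a 4.5-fold higher number from compound 1 to compound 3 (0.66 log units; beyond the scatter), so the arrangement of methoxy and methyl groups on the phenyl ring matters. The exchange of 2,6-dimethylpyridin-4-yl for 2-methoxy-5-methylphenyl gives a 16-fold higher number from compound 2 to compound 3 (1.21 log units; beyond the scatter), a larger step than the one between the other two aryl groups, and compound 2 remains lowest of the three. Nothing available explains the size of either step.

Compound 1 and compound 3 differ in both the methoxy placement and the added methyl, so the contribution of each remains unseparated. As far as these compounds go, it also remains open whether the lower number of compound 2 tracks its ring nitrogen or its two methyl groups, a question that a plain pyridin-4-yl or an unsubstituted phenyl would address.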